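Swapping a Phenylethyl for a Chlorophenyl Amine

The source may report more compounds than this note shows. Statements on the series, on what has been measured and on what is new or still open speak of the compounds shown alone.

Compound 1 `CCOC(=O)c1c(N2CCN(c3ccccc3)CC2)[nH]c2ccc(O)cc12`: > 20000 nM
Compound 2 `CCOC(=O)c1c(Nc2ccc(C)cc2)[nH]c2ccc(O)cc12`: 5200 nM
Compound 3 `CCOC(=O)c1c(NC(C)c2ccccc2)[nH]c2ccc(O)cc12`: 1200 nM

In an assay on isolated protein for inhibition of Polyunsaturated fatty acid 5-lipoxygenase (Homo sapiens) (on this read-out higher numbers stand for weaker inhibition and lower numbers for stronger inhibition), compound 1 reaches only a limit, > 20000 nM. Compound 2 gives 5200 nM, and compound 3 gives 1200 nM, the lowest of the two numbers; its nearest neighbour is compound 2, separated by a 4.3-fold lower number from compound 2 to compound 3 (0.64 log units; beyond the scatter). Compound 4 `CCOC(=O)c1c(Nc2cccc(Cl)c2)[nH]c2ccc(O)cc12` differs from compound 3 by 3-chlorophenyl in place of 1-phenylethyl on a nitrogen on an aromatic ring. Going by the values given here, only that single step bears on this change, and the new change largely runs the other way, back from a 1-phenylethyl to a singly substituted phenyl ring, though compound 2 carried a 4-methylphenyl rather than a 3-chlorophenyl. Compound 4 is therefore expected to give a higher number than compound 3, a 3.3-fold higher number from compound 3 to compound 4 (0.52 log units; beyond the scatter), estimated at 4000 nM with a range from 1200 nM to 13000 nM.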

Compound 4, half-maximal inhibitory concentration: 2400 nM
Beside the measured number, compound 4's estimate is 1.7-fold (0.22 log units) above it; measured number inside the range.
By their numbers in this assay, from the lowest: compounds 3 and 4 (each within the scatter of the next); then compound 2. At a limit, above all of these: compound 1.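

The step of a 2.0-fold higher number from compound 3 to compound 4 (0.30 log units; within the scatter) means that 3-chlorophenyl and 1-phenylethyl on this nitrogen cannot be told apart on this read-out. A phenyl ring placed directly on the nitrogen can therefore match 1-phenylethyl, and the choice of ring matters, with a 2.2-fold lower number from compound 2 to compound 4 (0.34 log units; beyond the scatter) for 3-chlorophenyl in place of 4-methylphenyl. Nothing measured here accounts for either step. That last step changes both the group on the ring and where it sits, so its cause stays open. A 4-chlorophenyl or 3-methylphenyl group could separate those two changes, and a benzyl group could show how 1-phenylethyl compares with its unbranched relative.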